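Carbonyl substituent changes on the shared core

This account rests on a few compounds, and the source may have more. Where it says the series, first, only, none or still open, it means among the compounds named here.

Measured in an assay on membranes from HeLa cells for displacement of a labelled ligand from adenosine receptor A3 (Homo sapiens), read by scintillation counting, with a stated time of 180 min, tested at 1 uM; on this read-out lower numbers stand for less inhibition and higher numbers for more inhibition at the one concentration tested (going by the name of the read-out):
compound 1 `COC(=O)C1=C(C)NC(=O)NC1c1cccs1` gives 3%
compound 2 `CC1=C(C(=O)OCC(C)C)C(c2cccs2)NC(=O)N1` gives 11%
compound 3 `CCN(CC)C(=O)C1=C(C)NC(=O)NC1c1cccs1` gives 31%

Compound 3 stands highest of the three numbers, with compound 2 nearest, a number 20 percentage points higher from compound 2 to compound 3 (beyond the scatter), and compound 1 furthest, a number 28 percentage points higher from compound 1 to compound 3 (beyond the scatter). The step between the two esters, a number 8 percentage points higher from compound 1 to compound 2 (within the scatter), stays within the scatter.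

Compound 4 `CCC(C)OC(=O)C1=C(C)NC(=O)NC1c1cccs1` differs from compound 3 at one place: sec-butoxy in place of diethylamino on a carbonyl carbon. This reverses the kind of change behind the two steps that raised the read-out: moving to the diethylamino group gave a number 20 percentage points higher from compound 2 to compound 3 (beyond the scatter) and a number 28 percentage points higher from compound 1 to compound 3 (beyond the scatter), whereas exchanging one alkoxy group for another gave only a number 8 percentage points higher from compound 1 to compound 2 (within the scatter). Going back from the diethylamino group to an alkoxy group of the same heavy-atom count as isobutoxy is therefore expected to lower the number in this assay by a modest step beyond the scatter. For compound 4 the expected step is a number 20 percentage points lower from compound 3 to compound 4 (beyond the scatter). Compound 4 is estimated to give 11% in this assay, within the range 0% to 25%.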

Compound 4, a percentage reported as inhibition, at one concentration (the size of the read-out at that concentration, not a potency): 7%
For compound 4 the middle estimate is 4 percentage points above the measured one, and the stated range covers the measured number.
By their numbers in this assay, from the lowest: compounds 1, 4 and 2 (each within the scatter of the next); then compound 3.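

On the carbonyl carbon in this assay, sec-butoxy in place of diethylamino gives a number 24 percentage points lower from compound 3 to compound 4 (beyond the scatter) and so takes away the higher number with an ester group of the same 5 heavy atoms. The alkyl group on the oxygen next to the carbonyl group makes no readable difference here, with a number 4 percentage points lower from compound 2 to compound 4 (within the scatter) for sec-butyl in place of isobutyl and a number 4 percentage points higher from compound 1 to compound 4 (within the scatter) for sec-butyl in place of methyl, leaving compound 3 as the only one of the four set apart from the others. No measurement at hand bears on why the diethylamino group stands apart from the esters.

Going by these compounds, whether the higher number belongs to diethylamino alone remains open, as a dimethylamino group, a longer dialkylamino chain or a carboxylic acid on this carbonyl carbon could show. Readings at one concentration also leave the potency of all four compounds open.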